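Ring exchange on the carbonyl: compound 1 to compound 3

The compounds below may be only part of what the source reports. "The series", "measured", "known", "first", "only" and "open" are said of these compounds alone.

In a physicochemical assay for lipophilicity, read by HPLC, in phosphate buffer, measured as octanol-water partition, with a stated time of 1 h, at pH 7.4 (on this read-out lower numbers stand for lower lipophilicity and higher numbers for higher lipophilicity), compound 1 (`C[C@@]1(c2cc(NC(=O)c3cnc(OCF)cn3)ccc2F)C=C(CF)OC(N)=N1`) gives 2.6 while compound 2 (`COc1cnc(C(=O)Nc2ccc(F)c([C@]3(C)C=C(CF)OC(N)=N3)c2)cn1`) gives 2.7 on the same scale, and these two readings lie within the scatter of each other. Compound 3 (`C[C@@]1(c2cc(NC(=O)c3coc(CF)n3)ccc2F)C=C(CF)OC(N)=N1`) has no reading yet. Its difference from compound 1 is 2-(fluoromethyl)-1,3-oxazol-4-yl in place of 5-(fluoromethoxy)pyrazin-2-yl on a carbonyl carbon and amounts to 2-(fluoromethyl)-1,3-oxazol-4-yl in place of 5-(fluoromethoxy)pyrazin-2-yl on a carbonyl carbon.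

Among the compounds with values here, only one measured step bears on this, and only in part. Within the data shown here, that step, a number 0.10 log units higher from compound 1 to compound 2 (within the scatter), puts hydrogen in place of fluoro within the group that leaves here, and no measured step exchanges the ring itself. Starting from compound 1 at 2.6 and with a smaller group entering by the count, a modest fall in this assay is expected, though the basis is thin. The estimated change is a number 0.40 log units lower from compound 1 to compound 3 (beyond the scatter) on this reasoning. For compound 3 the estimated value is 2.2 with an expected range from 1.7 to 2.7 in this series.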

Compound 3, distribution coefficient: 2.2
Compound 3: the middle estimate sits on the measured number at the digits printed; measured number inside the range.
By their numbers in this assay, from the lowest: compound 3; then compounds 1 and 2 (each within the scatter of the next).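

In this assay, within the data shown here, the place on a carbonyl carbon whose other neighbour is the amide-type nitrogen proves sensitive to exchange of the ring itself, with a number 0.40 log units lower from compound 1 to compound 3 (beyond the scatter) and a number 0.50 log units lower from compound 2 to compound 3 (beyond the scatter), whereas the only earlier step, changing the chain on the ring, was a number 0.10 log units higher from compound 1 to compound 2 (within the scatter) and stayed small. Both new steps end on 2-(fluoromethyl)-1,3-oxazol-4-yl and set out from different groups, 5-(fluoromethoxy)pyrazin-2-yl and 5-methoxypyrazin-2-yl, so the lower reading of compound 3 holds against each pyrazine compound shown, while ring size, heavy-atom count and acceptor count all change together in this one exchange. Nothing measured here gives a reason for these steps.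

Which of those changes carries the step remains open, and a 2-methyl-1,3-oxazol-4-yl group would show whether hydrogen in place of fluoro on the five-membered ring matters as little as it does on the six-membered ring. Also open, going by these compounds, is how this place responds to a five-membered ring bearing an amine, a carboxylic acid or a longer chain such as propyl.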